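Moving the bromine: 2-bromophenyl to 3-bromophenyl

The compounds below may be only part of what the source reports. "The series", "measured", "known", "first", "only" and "open" are said of these compounds alone.

In a functional assay (Homo sapiens) for inhibition (on this read-out lower numbers stand for stronger inhibition and higher numbers for weaker inhibition), compound 1 `CCCCOc1cccc(C(=O)/C=C/c2ccc(OC)cc2OC)c1` gives 65000 nM, compound 2 `COc1cccc(C(=O)/C=C/c2ccc(OC)cc2OC)c1` gives 42000 nM and compound 3 `COc1ccc(/C=C/C(=O)c2ccccc2Br)c(OC)c1` gives 35000 nM. These three numbers all lie within the scatter of one another, so compound 3 stands level with the other two and not apart from them.

The next compound, compound 4 `COc1ccc(/C=C/C(=O)c2cccc(Br)c2)c(OC)c1`, differs from compound 3 in one place, with 3-bromophenyl in place of 2-bromophenyl on a carbonyl carbon. The two have the same atoms, joined differently.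

Within the data shown here, only one measured step is available, and it does not touch this place. It is a 1.5-fold lower number from compound 1 to compound 2 (0.19 log units; within the scatter), with hydrogen in place of propyl on a saturated chain carbon bound to an oxygen on an aromatic ring. It bears on the question only indirectly, as a sign that one change in this small set left the number within the scatter. Among the measured compounds shown here, no measured compound tests the bromine change itself, so the expectation is weakly founded, and no shift beyond the scatter is expected in this assay. The expected change is a 1.1-fold higher number from compound 3 to compound 4 (0.06 log units; within the scatter). For compound 4 the estimated value is 40000 nM, with an expected range from 17000 nM to 90000 nM.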

Compound 4, half-maximal inhibitory concentration: 37000 nM
Compound 4: the middle estimate sits 1.1-fold (0.03 log units) above what was measured; the range from low to high includes it.
By their numbers in this assay, from the lowest: compounds 3, 4, 2 and 1 (each within the scatter of the next).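

Among these compounds, this is the first direct test of where the bromine sits: in this assay, 3-bromophenyl in place of 2-bromophenyl on a carbonyl carbon gives a 1.1-fold higher number from compound 3 to compound 4 (0.02 log units; within the scatter) and stays level, so this read-out does not separate the two bromine arrangements. The exchanges of a whole substituent on the aromatic carbon read the same way, with bromo in place of methoxy giving a 1.1-fold lower number from compound 2 to compound 4 (0.06 log units; within the scatter) and bromo in place of butoxy giving a 1.8-fold lower number from compound 1 to compound 4 (0.24 log units; within the scatter), so neither the kind of substituent nor its location has yet moved the number beyond the scatter in this small set. No independent measurement is available to explain this result.

What remains open is whether any group on this ring can shift the number at all, since every change shown so far keeps the compounds level with one another. An amine or a carboxylic acid in place of the bromine, or a longer chain on the oxygen than butoxy, could show whether this ring responds to a change of a different kind in this assay and whether the level seen here holds.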